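Chloro for Trifluoromethyl on Compound 1

The compounds below may be only part of what the source reports. "The series", "measured", "known", "first", "only" and "open" are said of these compounds alone.

Compound 1 `Cc1cc(-c2ccccc2)n(/C(N)=N/S(=O)(=O)c2cc(C)c(Cl)cc2SCc2cccc(C(F)(F)F)c2)n1` — compound 1 gives 40000 nM
Compound 2 `Cc1cc(S(=O)(=O)/N=C(\N)n2nccc2-c2ccccc2)c(SCc2ccccc2)cc1Cl` — compound 2 gives 18000 nM
Compound 3 `Cc1cc(S(=O)(=O)/N=C(\N)n2nccc2-c2ccccc2)c(SCc2ccc(C(F)(F)F)cc2)cc1Cl` — compound 3 gives 19000 nM

In an ADME assay on HaCaT cells (Homo sapiens) for cytotoxicity, read by MTT assay, with a stated time of 72 h (on this read-out lower numbers stand for stronger inhibition and higher numbers for weaker inhibition), compound 1 stands highest of the three numbers; compound 3 with 19000 nM lies nearest and compound 2 with 18000 nM furthest, both beyond the scatter. Compound 4 `Cc1cc(-c2ccccc2)n(/C(N)=N/S(=O)(=O)c2cc(C)c(Cl)cc2SCc2cccc(Cl)c2)n1` differs from compound 1 by chloro in place of trifluoromethyl on an aromatic carbon of a six-membered aromatic ring of carbon only, meta to a large group. Among the compounds with values here, the one measured step on that ring, a 1.1-fold higher number from compound 2 to compound 3 (0.02 log units; within the scatter), stays within the scatter, and no measured step exchanges trifluoromethyl for chloro. The step of no change at the digits printed from compound 1 to compound 4 (within the scatter) is therefore the expected outcome, with no movement beyond the scatter. For compound 4 the estimate is 40000 nM, with a range from 20000 nM to 80000 nM.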

Compound 4, half-maximal inhibitory concentration: 18000 nM
Estimate against measurement, compound 4: 2.2-fold (0.35 log units) above, outside the stated range (below it).
By their numbers in this assay, from the lowest: compounds 2, 4 and 3 (each within the scatter of the next); then compound 1.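

In this assay, chloro in place of trifluoromethyl on this aromatic carbon gives a 2.2-fold lower number from compound 1 to compound 4 (0.35 log units; beyond the scatter). The earlier step on this ring, a 1.1-fold higher number from compound 2 to compound 3 (0.02 log units; within the scatter), had shown no movement, so this result is the first to show a change on the ring moving the number beyond the scatter. No independent data bear on why the number moves here. What the compounds shown leave open is how an amine or a methoxy group on this same carbon would read, and whether either would stand nearer compound 1 or compound 4.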